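The source may report more compounds than this note shows. Statements on the series, on what has been measured and on what is new or still open speak of the compounds shown alone.

Of the compounds shown here, two sharing one core have been measured in a functional assay on A549 cells (Homo sapiens) for cytotoxicity, read by MTT assay, with a stated time of 72 h; a higher number here means a weaker inhibitor, a lower number a stronger inhibitor. Compound 1 (`COc1cccc(/C=C2\CCC/C(=C\c3ccc(Cl)cc3)C2=O)c1OC`) gives > 20000 nM, which is a limit of the assay and not a number. Compound 2 (`COc1cccc(/C=C2\CCC/C(=C\c3cccc(O)c3)C2=O)c1OC`) gives > 20000 nM, and this too is a limit and not a number. Both therefore sit at the limit of > 20000 nM in this assay, at which 2 of the 2 values shown sit, so compound 2 has no measured value against which a change could be read.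

Compound 3 (`COc1cccc(/C=C2\CCC/C(=C\c3cccc(Cl)c3Cl)C2=O)c1OC`) differs from compound 2 at one place: 2,3-dichlorophenyl in place of 3-hydroxyphenyl on a double-bonded chain carbon bound to a double-bonded ring carbon. On a double-bonded chain carbon bound to a double-bonded ring carbon, 2,3-dichlorophenyl stands in place of 3-hydroxyphenyl.

Going by the values given here, the only measured step at this place is a step that the two limits leave unreadable from compound 1 to compound 2, and it gives neither a size nor a direction. No step beyond the scatter is therefore expected in this assay, and a result reported only as a limit is the likeliest outcome. The estimated value for compound 3 is 20000 nM, with an expected range from 9000 nM to 40000 nM. This estimate means an expected a number no higher from compound 2 to compound 3 (the limit leaves the size open).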

Compound 3, half-maximal inhibitory concentration: > 20000 nM
Compound 3: only a limit was reported (the forecaster's own chance of this, stated with the estimate: 65%); the middle value lies on the limit itself.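

In this assay compound 3 gives > 20000 nM, which is a limit and not a number. The steps linking compound 1, compound 2 and compound 3 therefore cannot be read in size or direction: the limit of > 20000 nM in this assay, at which 3 of the 3 values shown sit. The compounds shown leave open whether any group on a double-bonded chain carbon bound to a double-bonded ring carbon changes the result in this assay.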